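Changing the Group on the Ring Amine Nitrogen

The source may report more compounds than this note shows. Statements on the series, on what has been measured and on what is new or still open speak of the compounds shown alone.

Two compounds have been measured in an assay on HEK293 cells for displacement of a labelled ligand from D(4) dopamine receptor (Homo sapiens), read by scintillation counting, with a stated time of 1 h; on this read-out higher numbers stand for weaker inhibition and lower numbers for stronger inhibition:
Compound 1, `COc1ccccc1N1CCN(CCCCc2cn(-c3ccccc3)nn2)CC1`, gives 486 nM.
Compound 2, `COc1ccccc1N1CCN(CCCCc2cn(-c3ccc4ccccc4c3)nn2)CC1`, gives 299 nM.

For the measured compounds named here, compound 2 holds the lowest of the two numbers, but the only measured step, a 1.6-fold lower number from compound 1 to compound 2 (0.21 log units; within the scatter), lies within the scatter. Compound 3, `Clc1cccc(N2CCN(CCCCc3cn(-c4ccc5ccccc5c4)nn3)CC2)c1Cl`, differs from compound 2 by 2,3-dichlorophenyl in place of 2-methoxyphenyl on an amine nitrogen in a ring. Going by the values given here, no measured step touches this part of the molecule; the one step measured changed a group elsewhere. Nothing shown therefore points to a step in this assay beyond the scatter in either direction. Compound 3 is expected at 300 nM, somewhere between 60 nM and 1500 nM, which means an expected step of a 1.0-fold higher number from compound 2 to compound 3 (0.00 log units; within the scatter).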

Compound 3, inhibition constant: > 2000 nM
Compound 3: a limit, no number (the forecaster's own chance of this, stated with the estimate: 5%); middle value at least 6.6-fold (0.82 log units) from the limit.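

In this assay, the group on the amine nitrogen in a ring clearly matters: 2,3-dichlorophenyl in place of 2-methoxyphenyl gives an at least 6.6-fold higher number from compound 2 to compound 3 (0.82 log units; beyond the scatter), the first step shown beyond the scatter. From the compounds shown here alone, compound 3 gives > 2000 nM, which is a limit of the assay and not a number, so the full size of the step remains unknown. For the compounds shown here, the one earlier step, at a different place in the molecule, stayed within the scatter.

The compounds shown leave open whether removing the methoxy group or adding the two chlorines drives this step. A plain phenyl or a 2-chlorophenyl on this nitrogen would help separate the two.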